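Series notes: substituent changes at the saturated chain carbon

This account rests on a few compounds, and the source may have more. Where it says the series, first, only, none or still open, it means among the compounds named here.

Measured in an assay on CHO cells for displacement of a labelled ligand from prostaglandin E2 receptor EP3 subtype (Homo sapiens), read by radioligand binding; on this read-out higher numbers stand for weaker inhibition and lower numbers for stronger inhibition:
compound 1, `CC(C)C(c1nnc[nH]1)c1ccc(-c2ccc3cccc(F)c3c2)[nH]c1=O`, compound 1 gives 12 nM
compound 2, `CC(C)C(c1ccc(-c2ccc3cccc(F)c3c2)[nH]c1=O)N1CCCCC1=O`, compound 2 gives 6.4 nM
compound 3, `CC(C)C(c1ccc(-c2ccc3cccc(F)c3c2)[nH]c1=O)N1CCNC1=O`, compound 3 gives 9.1 nM

Compound 3 holds the second highest of the three numbers; its nearest neighbour is compound 1 and its furthest is compound 2, and both gaps lie within the scatter, so no order among the three can be claimed. The steps at this position, a 1.3-fold lower number from compound 1 to compound 3 (0.12 log units; within the scatter) and a 1.4-fold higher number from compound 2 to compound 3 (0.15 log units; within the scatter), are both within the scatter, as is a 1.9-fold lower number from compound 1 to compound 2 (0.27 log units; within the scatter).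

Compound 4, `CC(C)C(c1ccc(-c2ccc3cccc(F)c3c2)[nH]c1=O)N1CCN/C1=N\C#N`, differs from compound 3 as follows: a group of 8 heavy atoms (4 carbon, 4 nitrogen; one five-membered non-aromatic ring with 2 hetero atoms) in place of a group of 6 heavy atoms (3 carbon, 2 nitrogen, 1 oxygen; one five-membered non-aromatic ring with 2 hetero atoms), on a saturated chain carbon bound to an aromatic carbon and a saturated chain carbon. Every change so far made at this saturated chain carbon has left the number within the scatter, so for compound 4 the step of a 1.0-fold lower number from compound 3 to compound 4 (0.00 log units; within the scatter) is expected to stay within the scatter as well, with no direction favoured. Compound 4 is therefore estimated at 9 nM, with a range from 3 nM to 27 nM in this assay.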

Compound 4, inhibition constant: 23 nM
Compound 4: the middle estimate sits 2.6-fold (0.41 log units) below what was measured, within the range that was stated.
By their numbers in this assay, from the lowest: compounds 2, 3, 1 and 4 (each within the scatter of the next, the first and the last beyond it).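

In this assay the saturated chain carbon gives its first steps beyond the scatter, with a 2.5-fold higher number from compound 3 to compound 4 (0.40 log units; beyond the scatter) and a 3.6-fold higher number from compound 2 to compound 4 (0.56 log units; beyond the scatter) both modest, so this position is not indifferent to every group placed on it. The five-membered non-aromatic ring stays in place in the first of these steps, so replacing the carbonyl of 2-oxoimidazolidin-1-yl with a nitrile-bearing imine is enough to give weaker inhibition, although a 1.9-fold higher number from compound 1 to compound 4 (0.28 log units; within the scatter) stays within the scatter and goes against any claim that compound 4 stands apart from all the others. Nothing measured in the material at hand accounts for this shift.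

On these data alone, whether the shift follows from the nitrile or from the imine itself remains open. Also open, as far as these compounds go, is how an open-chain urea, a primary amine or a carboxylic acid on this carbon would compare with compound 3.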